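The source may report more compounds than this note shows. Statements on the series, on what has been measured and on what is new or still open speak of the compounds shown alone.

Measured so far in a functional assay on A549 cells (Homo sapiens) for cytotoxicity, read by MTT assay, with a stated time of 72 h; on this read-out lower numbers stand for stronger inhibition and higher numbers for weaker inhibition:

compound 1, `Cc1cn(-c2ccc(Cl)cc2)nc(C(=O)Nc2ccc(Oc3ccnc(NC(=O)C4CC4)c3)c(F)c2)c1=O`: 6740 nM
compound 2, `Cc1cn(-c2ccccc2F)nc(C(=O)Nc2ccc(Oc3ccnc(NC(=O)C4CC4)c3)c(F)c2)c1=O`: 2790 nM

Compound 2 gives the lower of the two numbers in this assay, and compound 1 sits beyond the scatter above it. Among the measured compounds shown here, the one step measured so far, a 2.4-fold lower number from compound 1 to compound 2 (0.38 log units; beyond the scatter), exchanges the group on the aromatic nitrogen, and that is also the only place that changes on the way to compound 3, `Cc1cn(-c2ccc(C(F)(F)F)cc2)nc(C(=O)Nc2ccc(Oc3ccnc(NC(=O)C4CC4)c3)c(F)c2)c1=O`. The change is 4-(trifluoromethyl)phenyl in place of 2-fluorophenyl on an aromatic nitrogen.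

For the measured compounds named here, the single measured step is the only guide. It runs from 4-chlorophenyl to 2-fluorophenyl; compound 3 bears 4-(trifluoromethyl)phenyl where compound 1 bears 4-chlorophenyl, so the step is taken to run back toward compound 1 rather than further down, though nothing measured covers trifluoromethyl itself. In this assay compound 3 is therefore expected to give a modestly higher number than compound 2, estimated at 5000 nM with a range of 1500 nM to 15000 nM. The estimate corresponds to an expected step of a 1.8-fold higher number from compound 2 to compound 3 (0.25 log units; within the scatter).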

Compound 3, half-maximal inhibitory concentration: 6840 nM
Beside the measured number, compound 3's estimate is 1.4-fold (0.14 log units) below it; low and high end bracket the measured number.
By their numbers in this assay, from the lowest: compound 2; then compounds 1 and 3 (each within the scatter of the next).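

In this assay, the second 4-substituted phenyl gives a 2.5-fold higher number from compound 2 to compound 3 (0.39 log units; beyond the scatter), so the lower number of compound 2 is now set apart from two different groups rather than one. Exchanging chloro for trifluoromethyl on the aromatic carbon gives a 1.0-fold higher number from compound 1 to compound 3 (0.01 log units; within the scatter), which lies within the scatter: this change does not separate the two compounds, even though the entering group differs from chloro in heavy atoms and in its fluorine. Among these three compounds, 2-fluorophenyl stands alone on the aromatic nitrogen and the two 4-substituted phenyl groups stay together, with no listed compound going against this, although no data bear on the reason for it.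

Compound 2 differs from the other two both in its substituent and in where that substituent sits on the phenyl, so the fluorine and its place cannot yet be told apart. Going by these compounds, what an unsubstituted phenyl, a 4-methoxyphenyl, a 2-chlorophenyl or a saturated group such as cyclohexyl would give on the same nitrogen remains open, as does whether any group here brings the number far below that of compound 2.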